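A few compounds are considered here, and "the series" means these few. Any claim that something is new, unique, unknown or untested is made for them only; others in the source may bear on it.

Working notes on the series.

Among the compounds with values here, compound 2 `CCOc1nc(N)nc2ncc(-c3ccc(CC)cc3)nc12` gives the only number in the set: in a functional assay on cells (T-cell, Homo sapiens) for inhibition (a higher number here means a weaker inhibitor, a lower number a stronger inhibitor), compound 2 gives 8200 nM. Compound 1 `CC(C)Oc1nc(N)nc2ncc(-c3ccc(C#N)cc3)nc12` carries a cyano group where compound 2 carries an ethyl group, and also an isopropoxy group in place of the ethoxy group. In this assay compound 1 gives > 10000 nM, which is a limit of the assay and not a number. So compound 2 stands as the single measured value, with the other value in the set sitting at the limit of > 10000 nM in this assay, at which 1 of the 2 values shown sits. Within the data shown here, because the limit of > 10000 nM in this assay, at which 1 of the 2 values shown sits, is a limit, no step between compound 1 and compound 2 can be sized; the two values show only that compound 2 is measurable while compound 1 is not.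

Compound 3 `CCOc1nc(N)nc2ncc(-c3ccc(C#N)cc3)nc12` has not yet been measured in this assay. Relative to compound 2 the change is cyano in place of ethyl on an aromatic carbon, with the ethoxy group kept. Compound 3 therefore shares the cyano group of compound 1 and the ethoxy group of compound 2. Given that compound 1, the only cyano-bearing compound, sits at the limit of > 10000 nM in this assay, at which 1 of the 2 values shown sits, the expected step from compound 2 to compound 3 in this assay is a 1.8-fold higher number from compound 2 to compound 3 (0.26 log units; within the scatter), towards weaker inhibition and beyond the scatter. For compound 3 in this assay the expected value is 15000 nM, within 6000 nM to 40000 nM, with a fair chance that only a limit is reported.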

Compound 3, half-maximal inhibitory concentration: > 10000 nM
Compound 3: no number, only a limit; the forecaster's own chance of this, stated with the estimate: 60%; the middle value is on the limit's open side.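

With the ethoxy group kept, compound 3 isolates cyano in place of ethyl on an aromatic carbon para to a large group, a change that compound 1 could not isolate since it also carries the isopropoxy group, and in this assay compound 3 gives > 10000 nM, which is a limit of the assay and not a number. The single-place change from ethyl to cyano gives an at least 1.2-fold higher number from compound 2 to compound 3 (0.08 log units; that floor lies within the scatter), so the data bound the step from one side only and do not establish a change beyond the scatter. The step between the two cyano compounds cannot be read, and the effect of isopropoxy in place of ethoxy therefore remains unsized, with both compounds at the same limit: the limit of > 10000 nM in this assay, at which 2 of the 3 values shown sit.

The compounds shown leave open how far the value of compound 3 lies past its limit, and so the true size of the step from ethyl to cyano. They also leave open what a longer chain, an amine or a carboxylic acid at the same aromatic carbon would give in this assay, and whether isopropoxy in place of ethoxy alters the value when ethyl is kept.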